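The source may report more compounds than this note shows. Statements on the series, on what has been measured and on what is new or still open speak of the compounds shown alone.

Working notes: in a functional assay on K562 cells (Homo sapiens) for cytotoxicity, read by MTT assay, with a stated time of 24 h (on this read-out lower numbers stand for stronger inhibition and higher numbers for weaker inhibition), compound 2 (`COc1cc(/C=C2\CN(C)C/C(=C\c3ccc(Br)cc3)C2=O)cc(OC)c1`) gives 7420 nM, the higher of the two numbers so far and beyond the scatter from compound 1 (`CN1C/C(=C\c2ccc(C#N)cc2)C(=O)/C(=C/c2ccccc2F)C1`), which gives 2670 nM. Compound 3 (`COc1cc(/C=C2\CN(C)C/C(=C\c3ccc(C#N)cc3)C2=O)cc(OC)c1`) has cyano in place of bromo on an aromatic carbon, para to a large group: cyano in place of bromo on an aromatic carbon. Going by the values given here, no measured pair isolates this change. Compound 1 carries the same 4-cyanophenyl and gives 2670 nM, so a small fall in the number is expected, with the estimated 1.6-fold lower number from compound 2 to compound 3 (0.22 log units; within the scatter) lying within the scatter. The expected value for compound 3 is 4500 nM, with an estimated range of 1800 nM to 11000 nM.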

Compound 3, half-maximal inhibitory concentration: 4650 nM
For compound 3 the middle estimate is 1.0-fold (0.01 log units) below the measured one; the measured number falls inside the stated range.
By their numbers in this assay, from the lowest: compounds 1, 3 and 2 (each within the scatter of the next, the first and the last beyond it).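

In this assay, going by these compounds alone, the step of a 1.6-fold lower number from compound 2 to compound 3 (0.20 log units; within the scatter) gives the first direct reading of cyano in place of bromo on this aromatic carbon, para to a large group. With only this one place changed, the two groups cannot be told apart in this assay. Nothing on hand gives a reason for this result. 
On these data alone, whether an amine or a carboxylic acid at this place would give a step beyond the scatter stays open. Also open, as far as these compounds go, is whether cyano and bromo remain indistinguishable when the other side of the core is that of compound 1.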